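Urea series: trifluoromethyl in place of carbamoyl, solubility

A few compounds are considered here, and "the series" means these few. Any claim that something is new, unique, unknown or untested is made for them only; others in the source may bear on it.

The series holds two measured ureas on a shared core. Compound 1 `Cc1cc(NC(=O)Nc2ccccc2N)c2ccccc2n1` gives 51800 nM in a physicochemical assay for solubility, at pH 7.4; a lower number here means a less soluble compound, a higher number a more soluble compound. Compound 2 `Cc1cc(NC(=O)Nc2ccccc2C(N)=O)c2ccccc2n1` gives 200 nM in this assay and stands lowest of the two numbers; its nearest neighbour is compound 1, reached by a 260-fold lower number from compound 1 to compound 2 (2.41 log units; beyond the scatter). Compound 3 `Cc1cc(NC(=O)Nc2ccccc2C(F)(F)F)c2ccccc2n1` is not yet measured. Its change from compound 2 is trifluoromethyl in place of carbamoyl on an aromatic carbon. Going by the values given here, no measured step covers this change: the one step in hand, a 260-fold lower number from compound 1 to compound 2 (2.41 log units; beyond the scatter), concerns amino against carbamoyl and says nothing about trifluoromethyl, so it bears on compound 3 only by fixing the starting number of compound 2. Among the compounds with values here, with no comparable step, the expected move in this assay is none beyond the scatter, and the estimate rests on compound 2 alone with a wide range. For compound 3 the expected value in this assay is 300 nM, between 40 nM and 2500 nM, which means an expected step of a 1.5-fold higher number from compound 2 to compound 3 (0.18 log units; within the scatter).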

Compound 3, solubility: 3800 nM
For compound 3 the middle estimate is 13-fold (1.10 log units) below the measured one, and the stated range ends below it.
By their numbers in this assay, from the lowest: compound 2; then compound 3; then compound 1.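

In this assay, trifluoromethyl in place of carbamoyl gives a 19-fold higher number from compound 2 to compound 3 (1.28 log units; beyond the scatter) at this position, so the low number of compound 2 does not carry over to every replacement of the amino group of compound 1. Trifluoromethyl in place of amino still gives a 14-fold lower number from compound 1 to compound 3 (1.13 log units; beyond the scatter) on the same aromatic carbon, which places the three groups at three separate levels, with every step beyond the scatter and compound 3 in the middle. Going by these compounds alone, nothing measured so far bears on why the numbers fall in this order.

Where a nitrile, a carboxylic acid or a methoxy group would fall at this position remains open. Also open, on these data alone, is whether the same order of groups would hold at another place on the shared core.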